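Ethoxy in Place of Methylsulfanyl on a Stilbene

The compounds below may be only part of what the source reports. "The series", "measured", "known", "first", "only" and "open" are said of these compounds alone.

Measured so far:
compound 1, `COc1cc(/C=C\c2ccc(SC)cc2)cc(OC)c1OC`: 4 uM
compound 2, `COC(=O)/C(=C/c1cccc(OC)c1)c1cc(OC)c(OC)c(OC)c1`: 1.5 uM
compound 3, `COc1cc(/C=C/c2ccc(SC)cc2)cc(OC)c1OC`: 2.8 uM

In a functional assay on SK-MEL-5 cells (Homo sapiens) for cytotoxicity (on this read-out higher numbers stand for an effect only at larger amounts of compound and lower numbers for an effect already at smaller amounts), compound 1 has the highest of the three numbers, with compound 3 nearest and compound 2 furthest. For the measured compounds named here, the single measured step, a 1.4-fold lower number from compound 1 to compound 3 (0.15 log units; within the scatter), rests on the fact that compounds 1 and 3 differ only in the configuration as drawn and does not go beyond the scatter.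

Compound 4, `CCOc1ccc(/C=C\c2cc(OC)c(OC)c(OC)c2)cc1`, differs from compound 1 by ethoxy in place of methylsulfanyl on an aromatic carbon. Going by the values given here, none of the measured steps exchanges one group for another at this place, so nothing here speaks for a step beyond the scatter in either direction. Compound 4 is therefore expected to give about 4 uM, within 1.2 uM to 13 uM, meaning an estimated step of no change at the digits printed from compound 1 to compound 4 (within the scatter).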

Compound 4, concentration for half-maximal effect: 2.5 uM
The estimate for compound 4 lay 1.6-fold (0.20 log units) above the measured number, within the range that was stated.
By their numbers in this assay, from the lowest: compounds 2, 4, 3 and 1 (each within the scatter of the next, the first and the last beyond it).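

Exchanging methylsulfanyl for ethoxy on the aromatic carbon para to a large group gives a 1.6-fold lower number from compound 1 to compound 4 (0.20 log units; within the scatter) in this assay. The sulfur atom is therefore not required for this level of effect, and this place accepts a group with one more heavy atom. Nothing shown here gives a reason for this step.

From the compounds shown here alone, whether an amine, a carboxylic acid or a longer chain at this place would keep the number in this range remains open. So does whether the same exchange would behave alike with the double bond drawn E.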